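The compounds below may be only part of what the source reports. "The series", "measured", "known", "first", "only" and "open" are said of these compounds alone.

Measured so far:
compound 1 `COc1ccc(NC(=S)NC(=O)c2cn(-c3ccccc3)nc2-c2ccc(OC)cc2)cc1` gives 2570 nM in a functional assay on NCI-H460 cells (Homo sapiens) for inhibition, read by CCK-8 assay, with a stated time of 48 h; on this read-out higher numbers stand for weaker inhibition and lower numbers for stronger inhibition
compound 2 `O=C(NC(=S)Nc1ccc(Cl)cc1)c1cn(-c2ccccc2)nc1-c1ccc(F)cc1` gives 3090 nM in this assay

Of the compounds shown here, two have been measured. Compound 1 has the lower of the two numbers, but the gap to compound 2 falls within the usual scatter of repeated measurements, so the two cannot be told apart on this evidence. Compound 2 also differs from compound 1 in more than one place, so no clean single-change comparison is available.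

Compound 3 `COc1ccc(-c2nn(-c3ccccc3)cc2C(=O)NC(=S)Nc2ccc(C)cc2)cc1` has not yet been measured. It differs from compound 1 in one place: methyl in place of methoxy on an aromatic carbon, turning the (4-methoxyphenyl)amino part into (4-methylphenyl)amino. Within the data shown here, no measured pair isolates this swap, so the expectation rests only on the size of the change, which is small. The step of a 1.1-fold higher number from compound 1 to compound 3 (0.04 log units; within the scatter) is expected to stay within the scatter, with no clear direction. Compound 3 is accordingly estimated at 2800 nM, with a likely range from 1200 nM to 6500 nM.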

Compound 3, half-maximal inhibitory concentration: 2880 nM
The estimate for compound 3 lay 1.0-fold (0.01 log units) below the measured number; the measured number falls inside the stated range.
By their numbers in this assay, from the lowest: compounds 1, 3 and 2 (each within the scatter of the next).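

Among these compounds, compound 1 and compound 3 form the first pair here that differs in one place only, and in this assay putting methyl in place of methoxy, on an aromatic carbon para to a large group, gives a 1.1-fold higher number from compound 1 to compound 3 (0.05 log units; within the scatter). The swap removes the methoxy oxygen, a hydrogen-bond acceptor, yet the two compounds cannot be told apart on this read-out, so in this one pair the position accepts the change without a measurable penalty. Nothing measured on these compounds bears on why the two values match.

The compounds shown leave open whether this position responds to any group at all, since methoxy and methyl are the only two seen in an otherwise unchanged pair, and the chlorine of compound 2 comes with a second change elsewhere in the molecule. On these data alone, it also remains open whether an amine, a carboxylic acid or a longer chain such as butoxy at this place would move the number beyond the scatter.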